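The compounds below may be only part of what the source reports. "The series", "measured", "known", "first", "only" and "open" are said of these compounds alone.

Measured compounds:
compound 1, `O=C(Nc1cccc(-c2cccc(NC(=O)C(Cl)Cl)c2)c1)C(Cl)Cl`, 47900 nM
compound 2, `CSc1ccccc1-c1cc(NC(=O)C(Cl)Cl)cc(-c2ccccc2SC)c1`, 6510 nM
compound 3, `CCOc1ccccc1-c1cc(NC(=O)C(Cl)Cl)cc(-c2ccccc2OCC)c1`, 7280 nM

In a functional assay on A549 cells (Homo sapiens) for cytotoxicity, read by MTT assay, with a stated time of 68 h (a lower number here means a stronger inhibitor, a higher number a weaker inhibitor), compound 1 gives 47900 nM, the highest of the three numbers and therefore the weakest inhibitor in this set. Its nearest neighbour is compound 3, which in this assay gives 7280 nM, a gap beyond the scatter; compound 2, which in this assay gives 6510 nM, lies further off, also beyond the scatter. Both of these carry a single ((dichloromethyl)carbonyl)amino group on a core with three aromatic rings, whereas compound 1 carries two such groups on a core of two rings. Among the compounds with values here, no pair of compounds here differs in one place, so no measured step is available.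

Compound 4, `O=C(Nc1cccc(-c2ccccc2)c1)C(Cl)Cl`, has not yet been measured in this assay. It is derived from compound 1 by a single change: hydrogen in place of ((dichloromethyl)carbonyl)amino on an aromatic carbon. The change sits on an aromatic carbon of a six-membered aromatic ring of carbon only, meta to a large group. Within the data shown here, the data give no measured step for the loss of one ((dichloromethyl)carbonyl)amino group, so any expectation rests only on the weak value of compound 1, 47900 nM. Compound 4 is expected to show a step of a 1.4-fold higher number from compound 1 to compound 4 (0.13 log units; within the scatter), toward a weaker inhibitor, small and possibly not beyond the scatter. Compound 4 is therefore estimated at 65000 nM, with a range from 15000 nM to 250000 nM.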

Compound 4, half-maximal inhibitory concentration: 8900 nM
Compound 4: the middle estimate sits 7.3-fold (0.86 log units) above what was measured, and the stated range ends above it.
By their numbers in this assay, from the lowest: compounds 2, 3 and 4 (each within the scatter of the next); then compound 1.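

Within the data shown here, replacing the ((dichloromethyl)carbonyl)amino group with hydrogen on this aromatic carbon, meta to a large group, gives a 5.4-fold lower number from compound 1 to compound 4 (0.73 log units; beyond the scatter) in this assay and provides the first measured step in the set. The step is modest but beyond the scatter, and it shows that at this position the loss of the group goes with a stronger inhibitor, so compound 1 does not need its second ((dichloromethyl)carbonyl)amino group to register in this assay. Nothing measured here explains why the number falls with this change.

The compounds shown leave open whether the gain belongs to hydrogen itself or to the mere absence of the ((dichloromethyl)carbonyl)amino group, which a small replacement at the same aromatic carbon, such as an amine, a methyl group or a methoxy group, could help to separate. They also leave open what the remaining ((dichloromethyl)carbonyl)amino group of compound 4 contributes, for example whether a plain acetylamino group in its place would keep the number of compound 4 or lose it.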